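The source may hold more compounds than are shown below. What is called first, only, known or untested is meant among the compounds shown, and "the series" means these compounds.

Compound 2 `O=C(O)CCCCCCCCCCCOc1ccc2c(=O)c(-c3ccc(O)cc3)coc2c1` gives 130 nM in an assay (Cricetulus griseus) for inhibition of aldehyde dehydrogenase, mitochondrial (Homo sapiens); a lower number here means a stronger inhibitor, a higher number a weaker inhibitor. Going by the values given here, the only other number belongs to compound 1 `O=C(O)CCCCOc1ccc2c(=O)c(-c3ccc(O)cc3)coc2c1`, which gives 100 nM in this assay; the two sit together within the scatter. Compound 3 `O=C(O)CCCCCCOc1ccc2c(=O)c(-c3ccc(O)cc3)coc2c1` differs from compound 2 as follows: carboxy in place of 5-carboxypentyl on a saturated chain carbon, six bonds along the chain from an oxygen on an aromatic ring. Among the compounds with values here, the one measured step that bears on this is the chain-length change a 1.3-fold higher number from compound 1 to compound 2 (0.11 log units; within the scatter), a shift too small to count. Compound 3 carries a chain between the lengths of compound 1 and compound 2, so no step beyond the scatter is expected from compound 2 to compound 3 in this assay, and the expected step of a 1.2-fold lower number from compound 2 to compound 3 (0.07 log units; within the scatter) reflects that. For compound 3 the estimate in this assay is therefore 110 nM, with a range from 55 nM to 230 nM, resting on the two numbers given by compound 1 and compound 2.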

Compound 3, half-maximal inhibitory concentration: 50 nM
For compound 3 the middle estimate is 2.2-fold (0.34 log units) above the measured one; measured number below the stated range.
By their numbers in this assay, from the lowest: compounds 3, 1 and 2 (each within the scatter of the next, the first and the last beyond it).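

In this assay, going by these compounds alone, the change to carboxy from 5-carboxypentyl, on a saturated chain carbon six bonds along the chain from an oxygen on an aromatic ring, gives a 2.6-fold lower number from compound 2 to compound 3 (0.41 log units; beyond the scatter) and is the first step to pass the scatter, though only a modest one. Chain length can therefore move the number, but these compounds show no steady trend with length: a 2.0-fold lower number from compound 1 to compound 3 (0.30 log units; within the scatter) stays within the scatter, so compound 1 and compound 3 cannot be told apart.

On these data alone, it remains open whether a chain shorter than that of compound 1, or longer than that of compound 2, would shift the number further. As far as these compounds go, it is equally open whether an amide or a tetrazole at the chain end would hold it. Nothing available accounts for the step.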